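The source may hold more compounds than are shown below. What is called first, only, known or untested is meant among the compounds shown, and "the series" means these compounds.

Compound 3 `O=C(/C=C/c1cn(-c2ccccc2)nc1-c1ccncc1)c1ccsc1` gives 2200 nM in a functional assay on Huh-7 cells (Homo sapiens) for inhibition, read by sulforhodamine B assay, with a stated time of 72 h (a higher number here means a weaker inhibitor, a lower number a stronger inhibitor), which is the low end of the three numbers shown. Compound 2 `O=C(/C=C/c1cn(-c2ccccc2)nc1-c1cccnc1)c1ccccc1` gives 2300 nM in this assay, a value within the scatter of compound 3, while compound 1 `O=C(/C=C/c1cn(-c2ccccc2)nc1-c1ccsc1)c1ccccc1` gives 4700 nM in this assay, a gap beyond the scatter. Compound 4 `O=C(/C=C/c1cn(-c2ccccc2)nc1-c1ccncc1)c1ccccc1` differs from compound 3 in one place: phenyl in place of thiophen-3-yl on a carbonyl carbon. Within the data shown here, no measured step touches that carbonyl position; the only step available, a 2.0-fold lower number from compound 1 to compound 2 (0.31 log units; beyond the scatter), exchanges one ring for another on an aromatic carbon of the shared core and bears only loosely on the present change. With nothing measured at the changed place, the step of no change at the digits printed from compound 3 to compound 4 (within the scatter) is estimated to stay within the scatter. Compound 4 is therefore expected to give about 2200 nM in this assay, with a range from 1000 nM to 5000 nM.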

Compound 4, half-maximal inhibitory concentration: 1800 nM
Compound 4: the middle estimate sits 1.2-fold (0.09 log units) above what was measured; measured number inside the range.
By their numbers in this assay, from the lowest: compounds 4, 3 and 2 (each within the scatter of the next); then compound 1.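

At the carbonyl carbon, this assay does not separate phenyl from thiophen-3-yl: a 1.2-fold lower number from compound 3 to compound 4 (0.09 log units; within the scatter). On the aromatic carbon of the shared core, pyridin-4-yl and pyridin-3-yl are likewise not separated, a 1.3-fold lower number from compound 2 to compound 4 (0.11 log units; within the scatter), while pyridin-4-yl and thiophen-3-yl are, a 2.6-fold lower number from compound 1 to compound 4 (0.42 log units; beyond the scatter), in line with the earlier step between pyridin-3-yl and thiophen-3-yl. Nothing shown offers a reason for these steps. Going by these compounds, only these two aromatic rings are compared on the carbonyl carbon, so it remains open how an amine, a carboxylic acid or a longer chain there would read.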